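A Carbamoyl Variant of an Aryl Amide Growth Inhibitor

The source may report more compounds than this note shows. Statements on the series, on what has been measured and on what is new or still open speak of the compounds shown alone.

Measured so far:
Compound 1, `COc1cc(-c2nn(-c3cccc(NC(=O)c4cccc(C(F)(F)F)c4)c3)cc2-c2ccncc2)ccc1Cl`: 705 nM
Compound 2, `O=C(Nc1cccc(-n2cc(-c3ccncc3)c(-c3ccc(Cl)c(O)c3)n2)c1)Nc1ccc(Cl)c(C(F)(F)F)c1`: 660 nM

Both compounds were tested in a functional assay on MDA-MB-435 cells (Homo sapiens) for inhibition, read by sulforhodamine B assay, with a stated time of 48 h; a higher number here means a weaker inhibitor of growth, a lower number a stronger inhibitor of growth. Compound 1 gives 705 nM, the higher of the two numbers, while compound 2 gives 660 nM; the gap between them is within the scatter, so no order between them can be drawn. Compound 3, `COc1cc(-c2nn(-c3cccc(NC(=O)Nc4ccc(Cl)c(Cl)c4)c3)cc2-c2ccncc2)ccc1Cl`, has not been measured. It differs from compound 1 in one place: (3,4-dichlorophenyl)amino in place of 3-(trifluoromethyl)phenyl on a carbonyl carbon. Going by the values given here, no measured pair shows this change on its own, so the step must be judged from the two values at hand. Compound 2 already carries a carbamoyl-type link and a chlorinated ring and lands close to compound 1, so the step of a 1.2-fold lower number from compound 1 to compound 3 (0.07 log units; within the scatter) is expected to stay within the scatter. Compound 3 is therefore estimated at 600 nM, with a range from 250 nM to 1500 nM.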

Compound 3, concentration for 50% growth inhibition: 938 nM
Estimate against measurement, compound 3: 1.6-fold (0.19 log units) below, and the stated range covers the measured number.
By their numbers in this assay, from the lowest: compounds 2, 1 and 3 (each within the scatter of the next).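

In this assay, going by these compounds alone, the exchange of 3-(trifluoromethyl)phenyl for (3,4-dichlorophenyl)amino on a carbonyl carbon gives a 1.3-fold higher number from compound 1 to compound 3 (0.12 log units; within the scatter) and is the first reading of this change on the core of compound 1. At this position, then, the amide of compound 1 and the (3,4-dichlorophenyl)carbamoyl group of compound 3 cannot be told apart by growth inhibition, even though the exchange adds a hydrogen-bond donor and replaces trifluoromethyl with two chlorines. Nothing measured here explains this result.

The compounds shown leave open what the carbamoyl link and the ring substituents each contribute, as the two travel together in this step. They also leave open how this position would respond to a cyclohexyl ring, a longer alkyl chain or a ring bearing a carboxylic acid.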